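The source may report more compounds than this note shows. Statements on the series, on what has been measured and on what is new or still open speak of the compounds shown alone.

Three compounds share one core and differ only in the group on a double-bonded chain carbon bound to an aromatic carbon and a double-bonded chain carbon. Compound 1 `O=C(O)/C=C/c1ccc(/C(=C(/CCCl)c2ccccc2)c2ccc3[nH]ncc3c2)cc1` carries a 2-chloroethyl there, and in a functional assay on MCF7 cells (Homo sapiens) for cytotoxicity, read by CellTiter-Glo, with a stated time of 5 days (on this read-out higher numbers stand for weaker inhibition and lower numbers for stronger inhibition), compound 1 gives 9 nM. Compound 2 `O=C(O)/C=C/c1ccc(/C(=C(\c2ccccc2)C(F)F)c2ccc3[nH]ncc3c2)cc1` carries a difluoromethyl, and in this assay compound 2 gives 14 nM. Compound 3 `CC(C)/C(=C(/c1ccc(/C=C/C(=O)O)cc1)c1ccc2[nH]ncc2c1)c1ccccc1` carries an isopropyl, and in this assay compound 3 gives 4 nM, the lowest of the three numbers. The step of a 1.6-fold higher number from compound 1 to compound 2 (0.19 log units; within the scatter) lies within the scatter, whereas a 2.3-fold lower number from compound 1 to compound 3 (0.35 log units; beyond the scatter) and a 3.5-fold lower number from compound 2 to compound 3 (0.54 log units; beyond the scatter) both lie beyond it, so compound 3 stands as the strongest of the three in this assay.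

Compound 4 `O=C(O)/C=C/c1ccc(/C(=C(\c2ccccc2)C2CC2)c2ccc3[nH]ncc3c2)cc1` is not yet measured. It differs from compound 3 by cyclopropyl in place of isopropyl on a double-bonded chain carbon bound to an aromatic carbon and a double-bonded chain carbon. Within the data shown here, the two steps that bear on this position, a 2.3-fold lower number from compound 1 to compound 3 (0.35 log units; beyond the scatter) and a 3.5-fold lower number from compound 2 to compound 3 (0.54 log units; beyond the scatter), were each modest, and neither involved a cyclopropyl, so no measured step shows directly what this exchange does. Because the exchanges at this position have moved the number only by the modest amounts of a 2.3-fold lower number from compound 1 to compound 3 (0.35 log units; beyond the scatter) and a 3.5-fold lower number from compound 2 to compound 3 (0.54 log units; beyond the scatter), the swap of isopropyl for cyclopropyl is expected to do no more than that. Compound 4 is therefore expected to give about 6 nM in this assay, within a range from 2.5 nM to 15 nM. The expected step is a 1.5-fold higher number from compound 3 to compound 4 (0.18 log units; within the scatter), a change not beyond the scatter.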

Compound 4, half-maximal inhibitory concentration: 13 nM
Compound 4: the middle estimate sits 2.2-fold (0.34 log units) below what was measured; the measured number falls inside the stated range.
By their numbers in this assay, from the lowest: compound 3; then compounds 1, 4 and 2 (each within the scatter of the next).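

Cyclopropyl in place of isopropyl gives a 3.3-fold higher number from compound 3 to compound 4 (0.51 log units; beyond the scatter) in this assay, so this position separates two groups that have the same count of heavy atoms and differ in that one of them carries a ring. Cyclopropyl does not stand apart from the other groups, with a 1.1-fold lower number from compound 2 to compound 4 (0.03 log units; within the scatter) and a 1.4-fold higher number from compound 1 to compound 4 (0.16 log units; within the scatter), which leaves compounds 1, 2 and 4 without a clear order, while compound 3 with its isopropyl alone stands as the strongest of the four, its steps to each of the others lying beyond the scatter. Nothing measured alongside these numbers accounts for the step from isopropyl to cyclopropyl.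

The compounds shown leave open whether a tert-butyl or a cyclobutyl on this double-bonded chain carbon would give a number near that of compound 3 or near those of the other three. They also leave open how a group carrying a hydroxyl or an amine at this place would read in this assay, since all four groups shown have no hydrogen-bond donors or acceptors counted among those compared here.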